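The source may report more compounds than this note shows. Statements on the series, on what has been measured and on what is new or still open speak of the compounds shown alone.

Measured in a functional assay on HCT-116 cells (Homo sapiens) for antiproliferative activity, read by MTT assay, with a stated time of 48 h; on this read-out higher numbers stand for weaker inhibition and lower numbers for stronger inhibition:
- compound 1 `CCCC(CCO)n1cnc2c(Cl)nc(F)nc21`: 16500 nM
- compound 2 `CCCC(CCO)n1cnc2c(Cl)ncnc21`: > 50000 nM, a limit
- compound 3 `CCCCCC(CCO)n1cnc2c(N)nc(Cl)nc21`: > 50000 nM, a limit

Compound 1 alone gives a number. The others mark (the limit of > 50000 nM in this assay, at which 2 of the 3 values shown sit).

Compound 4 `CCCCCCCCC(CCO)n1cnc2c(Cl)nc(F)nc21` has not yet been measured in this assay. It departs from compound 1 by pentyl in place of hydrogen on a saturated chain carbon, four bonds along the chain from an aromatic nitrogen. This lengthens the chain and leaves the core of compound 1 unchanged.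

Within the data shown here, no measured step covers such a change. The only one, an at least 3.0-fold higher number from compound 1 to compound 2 (0.48 log units; beyond the scatter), alters the core and leaves the chain as it is, so it says little here. A longer chain also occurs in compound 3, whose core differs too. Compound 3 stands at > 50000 nM, a limit, which gives only a weak warning towards weaker inhibition.

With so little to go on, no step beyond the scatter is expected, though the uncertainty is wide. The expected change is a 1.4-fold lower number from compound 1 to compound 4 (0.14 log units; within the scatter). For compound 4 the estimated value is 12000 nM, with an expected range from 4000 nM to 40000 nM.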

Compound 4, half-maximal inhibitory concentration: 24200 nM
Beside the measured number, compound 4's estimate is 2.0-fold (0.30 log units) below it, and the stated range covers the measured number.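

In this assay, pentyl in place of hydrogen on this saturated chain carbon gives a 1.5-fold higher number from compound 1 to compound 4 (0.17 log units; within the scatter), the first step read at this position. With the core of compound 1 held fixed, this lengthening of the chain therefore moves the number by no more than the scatter. Compound 4 also gives a number rather than sitting at the limit of the assay: the limit of > 50000 nM in this assay, at which 2 of the 4 values shown sit.

The compounds shown leave open whether a still longer chain, or a phenyl ring or an amine carried on this same carbon, would keep the number within the scatter. They also leave open whether hydrogen in place of fluoro on the aromatic carbon would have the same effect with the longer chain of compound 4 as it has with the chain of compound 1.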